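A Sulfonyl-Amino Replacement on a Shared Lactone Core

A few compounds are considered here, and "the series" means these few. Any claim that something is new, unique, unknown or untested is made for them only; others in the source may bear on it.

Compound 1 `CCCCCCCCCCc1cn(C[C@H](O)[C@H]2OC(=O)C(OCc3ccccc3)=C2OCc2ccccc2)nn1` — in a functional assay on CFPAC-1 cells (Homo sapiens) for antiproliferative activity, read by MTT assay, with a stated time of 72 h (on this read-out higher numbers stand for weaker inhibition and lower numbers for stronger inhibition), compound 1 gives 40300 nM.
Compound 2 `CC(C)(C)c1cn(C[C@H](O)[C@H]2OC(=O)C(OCc3ccccc3)=C2OCc2ccccc2)nn1` — in this assay compound 2 gives 54900 nM.
Compound 3 `O=C1O[C@H]([C@@H](O)Cn2cc(CCCCl)nn2)C(OCc2ccccc2)=C1OCc1ccccc1` — in this assay compound 3 gives 58800 nM.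

Compound 3 carries the highest of the three numbers, yet both neighbours sit within the scatter of it: a 1.5-fold higher number from compound 1 to compound 3 (0.16 log units; within the scatter) and a 1.1-fold higher number from compound 2 to compound 3 (0.03 log units; within the scatter). The remaining step, a 1.4-fold higher number from compound 1 to compound 2 (0.13 log units; within the scatter), likewise stays within the scatter. Across these three compounds the group on the aromatic carbon was exchanged among decyl, tert-butyl and 3-chloropropyl without any shift in this assay beyond the scatter.

Compound 4 `O=C1O[C@H]([C@@H](O)Cn2cc(CNS(=O)(=O)c3ccc(Cl)cc3F)nn2)C(OCc2ccccc2)=C1OCc1ccccc1` differs from compound 3 by ((4-chloro-2-fluorophenyl)sulfonyl)amino in place of 2-chloroethyl on a saturated chain carbon bound to an aromatic carbon. Going by the values given here, none of the measured steps exchanges a chain for a sulfonyl-amino-linked aromatic ring, so none bears directly on this change; the only guide is that the three variations at this position left this assay flat within the scatter. Compound 4 is therefore expected to show a step of a 1.3-fold lower number from compound 3 to compound 4 (0.12 log units; within the scatter), with no direction beyond the scatter and a wide range given the absence of precedent. Compound 4 is estimated at 45000 nM, between 15000 nM and 120000 nM.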

Compound 4, half-maximal inhibitory concentration: 58200 nM
The estimate for compound 4 lay 1.3-fold (0.11 log units) below the measured number, and the stated range covers the measured number.
By their numbers in this assay, from the lowest: compounds 1, 2, 4 and 3 (each within the scatter of the next).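

Putting ((4-chloro-2-fluorophenyl)sulfonyl)amino in place of 2-chloroethyl on a saturated chain carbon bound to an aromatic carbon brings an aromatic ring and a hydrogen-bond donor to this position, yet this assay shows a 1.0-fold lower number from compound 3 to compound 4 (0.00 log units; within the scatter). Against the decyl compound the change gives a 1.4-fold higher number from compound 1 to compound 4 (0.16 log units; within the scatter), so this position stays flat within the scatter not only among chains but also when a ring-bearing sulfonyl-amino group enters. Nothing available here explains this lack of response.

From the compounds shown here alone, whether an amine, a carboxylic acid or a sulfonyl-amino group carrying a different aromatic ring would move the number beyond the scatter at this position remains open. Going by these compounds, the shared core is the same in all four compounds, so the effect of a change there on this assay is also open.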